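The source may hold more compounds than are shown below. What is called first, only, known or untested is meant among the compounds shown, and "the series" means these compounds.

Compound 1 `Cc1nc(N)c2c(-c3cccs3)cn([C@@H]3O[C@H](CO)[C@@H](O)[C@H]3O)c2n1`, compound 2 `Cc1nc(N)c2c(-c3ccsc3)cn([C@@H]3O[C@H](CO)[C@@H](O)[C@H]3O)c2n1` and compound 3 `Cc1nc(N)c2c(-c3ccccc3)cn([C@@H]3O[C@H](CO)[C@@H](O)[C@H]3O)c2n1` share one core and differ only in the ring on an aromatic carbon. In a functional assay on A549 cells (Homo sapiens), read by MTT assay, with a stated time of 72 h (a higher number here means a weaker inhibitor, a lower number a stronger inhibitor), compound 1 gives > 20000 nM, which is a limit of the assay. Compound 2 gives > 20000 nM, also a limit. Compound 3 gives > 20000 nM, again a limit. All three therefore sit at the limit of > 20000 nM in this assay, at which 3 of the 3 values shown sit, and compound 3 has no exact number.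

Compound 4 `Cc1nc(N)c2c(I)cn([C@@H]3O[C@H](CO)[C@@H](O)[C@H]3O)c2n1` carries iodo in place of phenyl on an aromatic carbon. The nearest guides are a step that the two limits leave unreadable from compound 1 to compound 3 and a step that the two limits leave unreadable from compound 2 to compound 3. Each only swaps one ring for another, so neither gives a size to carry over to iodo.

In this assay, only a move toward a stronger inhibitor could be read, and the expected step is modest: an at least 1.6-fold lower number from compound 3 to compound 4 (0.22 log units; that floor lies within the scatter). The value estimated for compound 4 is 12000 nM, within an expected range from 1500 nM to 30000 nM.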

Compound 4, half-maximal inhibitory concentration: 12100 nM
For compound 4 the middle estimate is 1.0-fold (0.00 log units) below the measured one; low and high end bracket the measured number.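

In this assay compound 4 is the only compound shown with an exact number at this position, 12100 nM, so a ring here is not the only group tested and replacing it with iodo gives a readable result. Against the ring compounds, the steps are an at least 1.6-fold lower number from compound 3 to compound 4 (0.21 log units; that floor lies within the scatter), an at least 1.6-fold lower number from compound 2 to compound 4 (0.21 log units; that floor lies within the scatter) and an at least 1.6-fold lower number from compound 1 to compound 4 (0.21 log units; that floor lies within the scatter), and each gives only a floor, so the full size stays unknown. The ring compounds remain at a limit of the assay: the limit of > 20000 nM in this assay, at which 3 of the 4 values shown sit.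

On these data alone, whether the readable number depends on iodo itself or simply on having no ring at this position stays open. As far as these compounds go, how a bromo group, an amine or a methyl group would read on this aromatic carbon also stays open.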